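Compound 2 to Compound 4: An Expected Clearance

A few compounds are considered here, and "the series" means these few. Any claim that something is new, unique, unknown or untested is made for them only; others in the source may bear on it.

Three compounds have numbers in an ADME assay on microsomes from liver (Homo sapiens) for metabolic stability, read by LC-MS, using NADPH, with stated times of 5 min and 30 min, tested at 1 uM; a higher number here means faster removal of the compound, a lower number slower removal. Compound 2 `CC1(C)CC(=O)N(c2cnc(NCc3c(F)ccc4c3CCO4)n3cnnc23)C1` gives 16 mL.min-1.g-1, the lowest of the three. Compound 1 `CN(C)Cc1ccc2c(c1)CN(c1cnc(NCc3c(F)ccc4c3CCO4)n3cnnc13)C2=O` gives 19 mL.min-1.g-1, which lies within the scatter of compound 2. Compound 3 `Cc1ncccc1-c1cnc(NCc2c(F)ccc3c2CCO3)c2cn[nH]c(=O)c12` gives 41 mL.min-1.g-1, which stands beyond the scatter above compound 2.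

Compound 4 `CN(c1cccnc1)c1cnc(NCc2c(F)ccc3c2CCO3)n2cnnc12` differs from compound 2 in one place: methyl(pyridin-3-yl)amino in place of 4,4-dimethyl-2-oxopyrrolidin-1-yl on an aromatic carbon. Going by the values given here, no measured pair differs in this way, so the expectation rests only on the spread of the three known numbers and on the change itself. For compound 4 a modest upward step a 1.6-fold higher number from compound 2 to compound 4 (0.21 log units; within the scatter) is expected, of a size that might just cross the scatter. Compound 4 is therefore estimated at 26 mL.min-1.g-1, with a range from 10 mL.min-1.g-1 to 65 mL.min-1.g-1.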

Compound 4, intrinsic clearance in microsomes: 80 mL.min-1.g-1
The estimate for compound 4 lay 3.1-fold (0.49 log units) below the measured number, and the stated range ends below it.
By their numbers in this assay, from the lowest: compounds 2 and 1 (each within the scatter of the next); then compounds 3 and 4 (each within the scatter of the next).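

In this assay, putting methyl(pyridin-3-yl)amino in place of 4,4-dimethyl-2-oxopyrrolidin-1-yl on this aromatic carbon gives a 5.0-fold higher number from compound 2 to compound 4 (0.70 log units; beyond the scatter). Going by these compounds alone, this is the first one-place comparison in the set, and it shows that the number at this position responds to the group carried there, with the change moving towards faster removal. Nothing available explains the step.

Going by these compounds, it remains open whether the pyridin-3-yl ring or the methyl goes with the higher number. On these data alone, how a morpholine or a primary amine on this carbon would read also remains open.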